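The compounds below may be only part of what the source reports. "The series", "measured", "known", "first", "only" and "open" are said of these compounds alone.

Measured compounds and their values in a functional assay on MCF7 cells (Homo sapiens) for cytotoxicity, read by CCK-8 assay, with a stated time of 72 h; on this read-out higher numbers stand for weaker inhibition and lower numbers for stronger inhibition:
compound 1 `C=CCn1c(=O)/c(=C\c2cccc(Cl)c2)[nH]c(=O)/c1=C\c1ccccc1OC` gives 5200 nM
compound 2 `C=CCn1c(=O)/c(=C\c2ccccc2Cl)[nH]c(=O)/c1=C\c1ccccc1OC` gives 4700 nM
compound 3 `C=CCn1c(=O)/c(=C\c2cc(Br)ccc2F)[nH]c(=O)/c1=C\c1ccccc1OC` gives 28100 nM

Compound 3 stands at the highest number of the three, that is the weakest inhibition shown in this assay. The steps to it are a 5.4-fold higher number from compound 1 to compound 3 (0.73 log units; beyond the scatter) and a 6.0-fold higher number from compound 2 to compound 3 (0.78 log units; beyond the scatter), both beyond the scatter, while a 1.1-fold lower number from compound 1 to compound 2 (0.04 log units; within the scatter) is within it.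

Compound 4 `C=CCn1c(=O)/c(=C\c2cccc(Br)c2)[nH]c(=O)/c1=C\c1ccccc1OC` is reached from compound 3 by hydrogen in place of fluoro on an aromatic carbon, which reads, cut one bond further out, as 5-bromo-2-fluorophenyl to 3-bromophenyl. For the measured compounds named here, no measured step removes a fluoro on its own. What bears on the change is that compound 4 carries a single halogen on that ring, as compound 1 does, and compound 1 sits at 5200 nM, while the step from the single-halogen pattern to the two-halogen pattern was a 5.4-fold higher number from compound 1 to compound 3 (0.73 log units; beyond the scatter). The expectation is therefore a step downward in this assay of about that size, though less certain, estimated as a 4.3-fold lower number from compound 3 to compound 4 (0.64 log units; beyond the scatter). Compound 4 is expected at 6500 nM in this assay, with a range from 2500 nM to 17000 nM.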

Compound 4, half-maximal inhibitory concentration: 5400 nM
For compound 4 the middle estimate is 1.2-fold (0.08 log units) above the measured one; the measured number falls inside the stated range.
By their numbers in this assay, from the lowest: compounds 2, 1 and 4 (each within the scatter of the next); then compound 3.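

In this assay the fluoro, ortho to a large group and para to a bromo group, is now changed on its own: hydrogen in its place gives a 5.2-fold lower number from compound 3 to compound 4 (0.72 log units; beyond the scatter) and so spans the whole gap between compound 3 and the single-halogen compounds with one atom. Bromo in place of chloro as the only change gives a 1.0-fold higher number from compound 1 to compound 4 (0.02 log units; within the scatter) and lies within the scatter, so this assay does not tell these two halogens apart in this series. 3-bromophenyl in place of 2-chlorophenyl gives a 1.1-fold higher number from compound 2 to compound 4 (0.06 log units; within the scatter) and also lies within the scatter, so among the compounds shown neither the halogen nor its place separates the single-halogen rings, and only compound 3, with its 5-bromo-2-fluorophenyl group, stands apart.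

Nothing shown gives a reason why the fluoro exchange moves the number while the halogen exchanges do not. Open too, on these data alone, is whether a fluoro on a ring without a bromo group would give a step of like size, and how an amine or a carboxylic acid at this place on the ring would read.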